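A few compounds are considered here, and "the series" means these few. Any claim that something is new, unique, unknown or untested is made for them only; others in the source may bear on it.

Measured compounds:
- compound 1 `Cc1ccccc1NC(=O)NCC1(c2ccccc2)CCCCC1`: 640 nM
- compound 2 `CC(C)c1ccccc1NC(=O)NCC1(c2ccccc2)CCCCC1`: 390 nM
- compound 3 `O=C(NCC1(c2ccccc2)CCCCC1)Nc1ccccc1C(F)(F)F`: 200 nM

In an assay on microsomes from intestine for inhibition of acyl-CoA:cholesterol acyltransferase (Oryctolagus cuniculus) (a higher number here means a weaker inhibitor, a lower number a stronger inhibitor), compound 1 gives the highest of the three numbers, so it is the starting point with the least favourable value. Its nearest neighbour is compound 2, reached by a 1.6-fold lower number from compound 1 to compound 2 (0.22 log units; within the scatter), a step that stays within the scatter. Its furthest is compound 3, reached by a 3.2-fold lower number from compound 1 to compound 3 (0.51 log units; beyond the scatter), a modest step beyond the scatter. Between those two, a 2.0-fold lower number from compound 2 to compound 3 (0.29 log units; within the scatter) is again within the scatter.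

Compound 4 `O=C(NCC1(c2ccccc2)CCCCC1)Nc1cccc(Cl)c1Cl` has not been measured in this assay. It differs from compound 1 by 2,3-dichlorophenyl in place of 2-methylphenyl on an amide-type nitrogen. Among the compounds with values here, no measured step changes the same groups, so only the general pattern bears on it: both changes on the aromatic carbon of compound 1 lowered the number, one within and one beyond the scatter. The account therefore expects a step in this assay of similar modest size in the same direction, a 2.1-fold lower number from compound 1 to compound 4 (0.33 log units; beyond the scatter). Compound 4 is thus estimated at 300 nM, with a range from 120 nM to 800 nM.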

Compound 4, half-maximal inhibitory concentration: 1300 nM
Beside the measured number, compound 4's estimate is 4.3-fold (0.64 log units) below it, outside the stated range (above it).
By their numbers in this assay, from the lowest: compounds 3, 2 and 1 (each within the scatter of the next, the first and the last beyond it); then compound 4.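

In this assay, the 2,3-dichlorophenyl group reverses the direction seen so far at this position on the amide-type nitrogen: a 2.0-fold higher number from compound 1 to compound 4 (0.31 log units; beyond the scatter), a modest rise beyond the scatter, whereas trifluoromethyl in place of methyl gave a 3.2-fold lower number from compound 1 to compound 3 (0.51 log units; beyond the scatter). Changes to the 2-methylphenyl group can therefore raise the number as well as lower it, so the lowering seen with compound 3 does not extend to every replacement here. Nothing available explains this reversal.

The compounds shown leave open which chlorine of the 2,3-dichlorophenyl group accounts for the rise, and whether a 2-chlorophenyl group alone would lower the number as in the earlier steps. On these data alone, how a methoxy group or a nitrile on the aromatic ring would fare also remains open.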